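The source may hold more compounds than are shown below. What is called first, only, known or untested is meant among the compounds shown, and "the series" means these compounds.

In a functional assay on 786-0 cells (Homo sapiens) for inhibition, read by sulforhodamine B assay, with a stated time of 48 h (on this read-out lower numbers stand for stronger inhibition of growth and higher numbers for weaker inhibition of growth), compound 1 (`S=C(N/N=C/c1cccs1)Nc1ccc(Cl)cc1`) gives 7400 nM, compound 2 (`S=C(N/N=C/c1cccs1)Nc1ccccc1`) gives 50400 nM, and compound 3 (`Cc1ccc(NC(=S)N/N=C/c2cccs2)cc1`) gives 19500 nM, which places compound 3 between the other two. Compound 4 (`COc1ccc(NC(=S)N/N=C/c2cccs2)cc1`) has methoxy in place of methyl on an aromatic carbon. The closest evidence comes from changes at this same carbon: a 2.6-fold lower number from compound 2 to compound 3 (0.41 log units; beyond the scatter), a 2.6-fold higher number from compound 1 to compound 3 (0.42 log units; beyond the scatter) and a 6.8-fold higher number from compound 1 to compound 2 (0.83 log units; beyond the scatter). All three are modest but beyond the scatter. For the measured compounds named here, none of the measured compounds carries methoxy, so the direction stays open, and in this assay only a small step, possibly none beyond the scatter, is expected. The expected step is a 1.0-fold higher number from compound 3 to compound 4 (0.01 log units; within the scatter). For compound 4 the estimated value is 20000 nM, with an expected range from 8000 nM to 50000 nM.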

Compound 4, concentration for 50% growth inhibition: > 100000 nM
Compound 4 gave a limit, no number (the forecaster's own chance of this, stated with the estimate: 5%); at least 5.0-fold (0.69 log units) between middle value and limit.
By their numbers in this assay, from the lowest: compound 1; then compound 3; then compound 2. At a limit, above all of these: compound 4.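

Compound 4 gives no number in this assay, only a limit: the limit of > 100000 nM in this assay, at which 1 of the 4 values shown sits. On this aromatic carbon, para to a large group, methoxy moves the read-out further from methyl than any earlier change did, with an at least 5.1-fold higher number from compound 3 to compound 4 (0.70 log units; beyond the scatter) and, measured against chloro, an at least 13-fold higher number from compound 1 to compound 4 (1.13 log units; beyond the scatter). Chloro and methyl both gave lower numbers than hydrogen, but methoxy does not, with an at least 1.9-fold higher number from compound 2 to compound 4 (0.29 log units; that floor lies within the scatter). The compounds shown leave open whether a hydroxyl, an ethyl or a fluoro at this carbon would side with methoxy or with chloro.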